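Swapping methoxy for amino on a kinase binder

The source may report more compounds than this note shows. Statements on the series, on what has been measured and on what is new or still open speak of the compounds shown alone.

Compounds 1, 2 and 3 share one core and differ only in the aryl group attached to it. Compound 1 `CCCS(=O)(=O)Nc1ccc(F)c(C(=O)c2n[nH]c3ncc(-c4ccccc4Cl)cc23)c1F` carries a 2-chlorophenyl, compound 2 `CCCS(=O)(=O)Nc1ccc(F)c(C(=O)c2n[nH]c3ncc(-c4ccccc4F)cc23)c1F` a 2-fluorophenyl and compound 3 `CCCS(=O)(=O)Nc1ccc(F)c(C(=O)c2n[nH]c3ncc(-c4ccc(OC)cc4)cc23)c1F` a 4-methoxyphenyl. In an assay for binding affinity to dual specificity mitogen-activated protein kinase kinase 4 (Homo sapiens), read by KINOMEscan, tested at 100 nM (on this read-out higher numbers stand for a weaker effect at the one concentration tested and lower numbers for a stronger effect), compound 1 gives 9.3%, compound 2 gives 2% and compound 3 gives 4.2%. Compound 3 thus sits between the other two numbers, and both steps that reach it, a number 5.1 percentage points lower from compound 1 to compound 3 (within the scatter) and a number 2.2 percentage points higher from compound 2 to compound 3 (within the scatter), lie within the scatter, as does a number 7.3 percentage points lower from compound 1 to compound 2 (within the scatter). Compound 4 `CCCS(=O)(=O)Nc1ccc(F)c(C(=O)c2n[nH]c3ncc(-c4ccc(N)cc4)cc23)c1F` is the next variation: amino in place of methoxy on an aromatic carbon. The three measured steps all concern that same aryl group and none of them rose above the scatter, so no movement beyond the scatter is expected in this assay from this change either. The expected step is a number 0.8 percentage points higher from compound 3 to compound 4 (within the scatter). Compound 4 is expected to give 5%, with a range from 1% to 15%.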

Compound 4, a percentage reported as activity, at one concentration (the size of the read-out at that concentration, not a potency): 0.1%
Beside the measured number, compound 4's estimate is 4.9 percentage points above it, and the stated range ends above it.
By their numbers in this assay, from the lowest: compounds 4, 2, 3 and 1 (each within the scatter of the next).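

Amino in place of methoxy adds a hydrogen-bond donor at this spot, para to a large group, and the exchange gives a number 4.1 percentage points lower from compound 3 to compound 4 (within the scatter) in this assay and so adds a new kind of change at this position without any movement beyond the scatter. The comparisons with the two halogen-bearing aryl groups read the same way, with a number 1.9 percentage points lower from compound 2 to compound 4 (within the scatter) and a number 9.2 percentage points lower from compound 1 to compound 4 (within the scatter) as well. Nothing available explains these numbers, and no measurement on any group's properties bears on them.

Still open, going by these compounds, is whether a carboxylic acid or a longer chain in the same place would move the number beyond the scatter. On these data alone, a reading at one concentration is not a potency, so any real gap between compound 3 and compound 4 in binding strength remains unknown.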